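This account rests on a few compounds, and the source may have more. Where it says the series, first, only, none or still open, it means among the compounds named here.

Measured compounds:
compound 1, `CC(C)C[C@H](N)C(=O)NS(=O)(=O)c1cccc(-c2ccccc2)c1`, 3400 nM
compound 2, `CC(C)C[C@H](N)C(=O)NS(=O)(=O)c1cccc(-c2cccc(N)n2)c1`, 850 nM
compound 3, `CC(C)C[C@H](N)C(=O)NS(=O)(=O)c1cccc(-c2cc(-c3ccccc3)nc(N)n2)c1`, 33 nM

These three compounds share one core and differ only in the aromatic group attached to it. In an assay on isolated protein for inhibition of leucine--tRNA ligase, cytoplasmic (Homo sapiens) (a lower number here means a stronger inhibitor, a higher number a weaker inhibitor), compound 2 gives 850 nM, which places it second highest of the three numbers: compound 1 gives the higher value 3400 nM, while compound 3 gives the lowest, 33 nM.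

Compound 4, `CC(C)C[C@H](N)C(=O)NS(=O)(=O)c1cccc(-c2ccnc(N)n2)c1`, has not yet been measured. It differs from compound 2 in one place: 2-aminopyrimidin-4-yl in place of 6-aminopyridin-2-yl on an aromatic carbon.

For the measured compounds named here, only one measured step in this set bears on the change. Replacing phenyl with 6-aminopyridin-2-yl gave a 4.0-fold lower number from compound 1 to compound 2 (0.60 log units; beyond the scatter). That step introduced the amino group and a ring nitrogen; the step to compound 4 keeps both and adds a further ring nitrogen. Going by the values given here, compound 3 also carries a 2-aminopyrimidin-4-yl group, but with an additional phenyl, so its value cannot be separated into the two contributions, and no step between compound 3 and compound 4 is available.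

A modest shift toward a lower number is therefore expected, and compound 4 is estimated at 500 nM, with a range of 150 nM to 1800 nM, corresponding to an expected step of a 1.7-fold lower number from compound 2 to compound 4 (0.23 log units; within the scatter).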

Compound 4, half-maximal inhibitory concentration: 3900 nM
Compound 4: the middle estimate sits 7.8-fold (0.89 log units) below what was measured; the measured number lies above the stated range.
By their numbers in this assay, from the lowest: compound 3; then compound 2; then compounds 1 and 4 (each within the scatter of the next).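

In this assay, the swap to 2-aminopyrimidin-4-yl, on an aromatic carbon meta to a large group, gives a 4.6-fold higher number from compound 2 to compound 4 (0.66 log units; beyond the scatter), so the gain that came with 6-aminopyridin-2-yl does not survive one further ring nitrogen. Set against the plain phenyl of the first compound, the same group gives a 1.1-fold higher number from compound 1 to compound 4 (0.06 log units; within the scatter), which means that, without a further substituent, 2-aminopyrimidin-4-yl cannot be told apart from phenyl at this position. Removing the extra phenyl gives a 120-fold higher number from compound 3 to compound 4 (2.07 log units; beyond the scatter), so the low number of compound 3 depends on that phenyl and not on the 2-aminopyrimidin-4-yl group alone, and nothing measured here explains either of these shifts.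

Still open, on these data alone, is whether a phenyl added to the 6-aminopyridin-2-yl group would bring a similar gain, and whether a smaller group such as methyl in place of the extra phenyl would keep part of it. Also open, as far as these compounds go, is how much the amino group itself contributes, which a hydroxyl or a methoxy group in its place could help to show.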